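Plasma half-life projection for compound 4

The source may hold more compounds than are shown below. What is called first, only, known or untested is meant among the compounds shown, and "the series" means these compounds.

Compound 3 `COC(=O)c1cc(N)c(Nc2ccc(C#N)cc2)cc1Oc1c(C)cc(/C=C/C#N)cc1C` holds the highest number of the three measured compounds in an ADME assay on a cell-free system (plasma, Homo sapiens) for metabolic stability, read by LC-MS, tested at 10 ug/mL (a higher number here means that the compound lasts longer, a lower number that the compound disappears faster), where compound 3 gives 89 h. Its nearest neighbour is compound 1 `COCCOC(=O)c1cc(N)c(Nc2ccc(C#N)cc2)cc1Oc1c(C)cc(/C=C/C#N)cc1C`, which in this assay gives 62 h; the step of a 1.4-fold higher number from compound 1 to compound 3 (0.16 log units; within the scatter) lies within the scatter. Furthest off is compound 2 `Cc1cc(/C=C/C#N)cc(C)c1Oc1cc(Nc2ccc(C#N)cc2)c(N)cc1C(=O)N1CC1`, which in this assay gives 12 h; the step of a 7.4-fold higher number from compound 2 to compound 3 (0.87 log units; beyond the scatter) is beyond the scatter, as is the step of a 5.2-fold lower number from compound 1 to compound 2 (0.71 log units; beyond the scatter).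

Compound 4 `CNC(=O)c1cc(N)c(Nc2ccc(C#N)cc2)cc1Oc1c(C)cc(/C=C/C#N)cc1C` is the next member of the series. Relative to compound 3 the change is methylamino in place of methoxy on a carbonyl carbon. All three measured steps exchange the group on that same carbonyl carbon, so all three bear on this one. The exchange of methoxy for methoxyethoxy left the number within the scatter, seen in a 1.4-fold higher number from compound 1 to compound 3 (0.16 log units; within the scatter), whereas the exchange involving aziridin-1-yl moved it by a modest amount, seen in a 7.4-fold higher number from compound 2 to compound 3 (0.87 log units; beyond the scatter). Methylamino, like aziridin-1-yl, places a nitrogen on the carbonyl carbon rather than an oxygen, so for compound 4 a modest fall in this assay is expected, estimated as a 2.2-fold lower number from compound 3 to compound 4 (0.35 log units; beyond the scatter). The estimate for compound 4 in this assay is 40 h, with a range from 15 h to 90 h.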

Compound 4, half-life in the plasma assay: 72 h
The estimate for compound 4 lay 1.8-fold (0.26 log units) below the measured number; measured number inside the range.
By their numbers in the plasma assay, from the lowest: compound 2; then compounds 1, 4 and 3 (each within the scatter of the next).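

In the plasma assay, methylamino on the carbonyl carbon does not behave like aziridin-1-yl: its number stays level with the two ester compounds (a 1.2-fold lower number from compound 3 to compound 4 (0.09 log units; within the scatter); a 1.2-fold higher number from compound 1 to compound 4 (0.06 log units; within the scatter)) and remains well clear of compound 2 (a 6.0-fold higher number from compound 2 to compound 4 (0.78 log units; beyond the scatter)). A nitrogen on this carbonyl carbon is therefore not enough by itself to bring the number down, with compound 2 the only one of the four that stands apart, and the position tolerates methoxy, 2-methoxyethoxy and methylamino alike in this assay. The same exchange of methoxycarbonyl to methylcarbamoyl is far from silent in a physicochemical assay for lipophilicity, read by HPLC, measured as octanol-water partition, with a stated time of 24 h, at pH 7.4 (on this read-out lower numbers stand for lower lipophilicity and higher numbers for higher lipophilicity), where compound 3 gives 4.15 and compound 4 gives 2.65, so the half-life held within the scatter across a large fall in measured lipophilicity: the measured partition coefficient of compound 3, 4.15, and of compound 4, 2.65, a number 1.50 log units lower (beyond the scatter)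

Still open, from the compounds shown here alone, is whether the low number of compound 2 goes with the ring of aziridin-1-yl or with the absence of a hydrogen on the amide nitrogen, a question that dimethylamino on the same carbonyl carbon would separate. Also open, going by these compounds, is how far the level number extends to a longer chain on the amide nitrogen, such as ethylamino, or to a carboxylic acid at this place.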